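This account rests on a few compounds, and the source may have more. Where it says the series, first, only, none or still open, it means among the compounds named here.

In an ADME assay on microsomes from liver (Rattus norvegicus) for metabolic stability, using NADPH, with a stated time of 10 min (on this read-out higher numbers stand for a more stable compound and lower numbers for a less stable compound), compound 1 `CN(C[C@H]1Cc2c(cccc2N2C[C@H]3CNC[C@H]3C2)CN1)[C@H]1CCCc2cccnc21` gives 38.1% and compound 2 `CN(C)C1CCN(c2cccc3c2C[C@H](CN(C)[C@H]2CCCc4cccnc42)NC3)CC1` gives 52.4%. Compound 2 therefore holds the higher of the two numbers. For the measured compounds named here, the only measured step, a number 14.3 percentage points higher from compound 1 to compound 2 (beyond the scatter), is modest but beyond the scatter. In that step, a group with one six-membered non-aromatic ring replaced a group with 2 five-membered non-aromatic rings on an aromatic carbon.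

Compound 3 `CN1CC[C@H]2CN(c3cccc4c3C[C@H](CN(C)[C@H]3CCCc5cccnc53)NC4)C[C@H]21` keeps the shared core and changes that same place: a group of 9 heavy atoms (7 carbon, 2 nitrogen; 2 five-membered non-aromatic rings with 1 hetero atom each) in place of a group of 9 heavy atoms (7 carbon, 2 nitrogen; one six-membered non-aromatic ring with 1 hetero atom), on an aromatic carbon. The 4-(dimethylamino)piperidin-1-yl group leaves, and the entering group again has 2 five-membered non-aromatic rings with 1 hetero atom each. The group in compound 1 has the same ring count but one heavy atom fewer, so the two groups are not identical. The step to compound 2, a number 14.3 percentage points higher from compound 1 to compound 2 (beyond the scatter), therefore bears on this change only in reverse and only in part, and it is a single step. A modest fall of somewhat smaller size is expected, and the estimated change is a number 9.4 percentage points lower from compound 2 to compound 3 (within the scatter). The expected value for compound 3 is 43%, with an estimated range of 28% to 58%.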

Compound 3, percent of the compound remaining: 1.78%
Beside the measured number, compound 3's estimate is 41.2 percentage points above it; measured number outside the range, below it.
By their numbers in this assay, from the lowest: compound 3; then compound 1; then compound 2.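

In this assay, this aromatic carbon proves far more sensitive to the choice of amine group than the first step showed: a number 50.6 percentage points lower from compound 2 to compound 3 (beyond the scatter) even though the 4-(dimethylamino)piperidin-1-yl group and the group that enters have the same counts of heavy atoms, carbon, nitrogen, hydrogen-bond donors and hydrogen-bond acceptors. Ring count does not sort the series either, as the groups of compound 1 and compound 3 both carry 2 five-membered non-aromatic rings with 1 hetero atom each, and yet a number 36.3 percentage points lower from compound 1 to compound 3 (beyond the scatter) on this read-out. Nothing available gives a reason for the low number of compound 3.

From the compounds shown here alone, it remains open whether that low number goes with the methyl on the ring nitrogen of the entering group, with the way its two rings are joined, or with its 2 defined stereocentres. Going by these compounds, it is also open whether a morpholin-4-yl group, a piperazin-1-yl group or an open-chain dimethylamino chain on the same aromatic carbon would stay near compound 2 at 52.4% or fall towards compound 3.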